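Cyclopentyl for furanylmethyl on a quinazoline-type amine

The compounds below may be only part of what the source reports. "The series", "measured", "known", "first", "only" and "open" are said of these compounds alone.

The series shares one core, seen in compound 1 `CNc1nc(NCc2ccccc2)nc2ccccc12`, which in an ADME assay on J774.A1 cells (Mus musculus) for inhibition, read by MTT assay, with a stated time of 72 h (on this read-out lower numbers stand for an effect already at smaller amounts and higher numbers for an effect only at larger amounts of compound), gives 15000 nM. Compound 2 `CNc1nc(NCc2ccco2)nc2ccccc12` differs from it only in the group on the ring nitrogen; for compound 2 the entry in this assay reads "not determined" (no result reported), so compound 2 stands without a single number in that read-out, and nothing can be said of how it compares with compound 1. Compound 3 `CNc1nc(NC2CCCC2)nc2ccccc12` is the next member and remains to be tested. Its change from compound 2 is cyclopentyl in place of (furan-2-yl)methyl on a nitrogen on an aromatic ring. Among the compounds with values here, no measured step between neighbouring compounds exists here to anchor the size of this change; on the numbers available, the author expects the step from compound 2 to compound 3 in this assay to be small, no larger than the usual scatter, in either direction. Compound 3 is therefore estimated at 15000 nM, within a range from 5000 nM to 50000 nM.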

Compound 3, half-maximal effective concentration: 39000 nM
For compound 3 the middle estimate is 2.6-fold (0.41 log units) below the measured one; the measured number falls inside the stated range.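

In this assay, within the data shown here, compound 2 has no single number, so no step from it to compound 3 can be read. The compounds shown leave open how cyclopentyl and (furan-2-yl)methyl compare on this nitrogen, and nothing at hand explains the value of compound 3.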